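The compounds below may be only part of what the source reports. "The series", "measured", "known", "first", "only" and "open" are said of these compounds alone.

Measured so far:
compound 1, `COc1ccc(COc2cc([N+](=O)[O-])ccc2N(C)S(C)(=O)=O)cc1`, 470 nM
compound 2, `CS(=O)(=O)Nc1ccc([N+](=O)[O-])cc1OCc1ccc(Cl)cc1`, 290 nM

In an assay on SK-BR-3 cells for inhibition of Aromatase (Homo sapiens) (a lower number here means a stronger inhibitor, a higher number a weaker inhibitor), compound 2 gives the lower of the two numbers, yet compound 1 lies within the usual scatter of it, so the two cannot be told apart. Compound 3, `CN(c1ccc([N+](=O)[O-])cc1OCc1ccc(Cl)cc1)S(C)(=O)=O`, differs from compound 2 by methyl in place of hydrogen on a sulfonamide nitrogen. Among the measured compounds shown here, no measured pair isolates this change, so its effect is unknown. The step of a 1.4-fold higher number from compound 2 to compound 3 (0.14 log units; within the scatter) is expected to stay within the scatter. Compound 3 is therefore estimated at about 400 nM, with a range from 150 nM to 1200 nM.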

Compound 3, half-maximal inhibitory concentration: 2400 nM
Compound 3: the middle estimate sits 6.0-fold (0.78 log units) below what was measured; measured number outside the range, above it.
By their numbers in this assay, from the lowest: compounds 2 and 1 (each within the scatter of the next); then compound 3.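

In this assay, the sulfonamide nitrogen proves sensitive to a single added carbon: methyl in place of hydrogen gives a clear loss (an 8.3-fold higher number from compound 2 to compound 3 (0.92 log units; beyond the scatter)). Once that methyl is present, the group on the aromatic carbon also matters, as chloro in place of methoxy gives a further separate step (a 5.1-fold higher number from compound 1 to compound 3 (0.71 log units; beyond the scatter)). Nothing available explains either step. From the compounds shown here alone, it remains open whether the methyl step would be the same size in a compound carrying methoxy. Also open, going by these compounds, is whether an ethyl group or a longer chain on that nitrogen would behave like methyl.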